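A few compounds are considered here, and "the series" means these few. Any claim that something is new, unique, unknown or untested is made for them only; others in the source may bear on it.

Working notes on the styryl benzyl sulfone pair measured so far in a functional assay on H157 cells (Homo sapiens) for antiproliferative activity, read by trypan blue exclusion; a higher number here means a weaker inhibitor, a lower number a stronger inhibitor.

Compound 1 `COc1cc(OC)c(/C=C/S(=O)(=O)Cc2ccc(Cl)cc2)c(OC)c1` gives 15000 nM in this assay. Compound 2 `COc1ccc(CS(=O)(=O)/C=C/c2c(OC)cccc2OC)cc1` gives 700 nM in this assay. Going by the values given here, compound 2 therefore holds the lowest of the two numbers recorded, and the only neighbour, compound 1, sits at a markedly higher value; the two structures differ in more than one place, so no single step is drawn between them, and the numbers show only that compound 2 is the stronger inhibitor of the two.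

The next compound, compound 3 `COc1ccc(CS(=O)(=O)/C=C/c2c(OC)cc(OC)cc2OC)cc1`, is not yet measured in this assay. It follows from compound 2 by one change: methoxy in place of hydrogen on an aromatic carbon. Nothing else in the molecule is altered.

Among the compounds with values here, no measured step of this kind exists, so the expectation rests on compound 2 alone. A small step is expected, most likely none beyond the scatter, with a slight lean toward a lower number rather than a higher one; the estimated step is a 1.4-fold lower number from compound 2 to compound 3 (0.15 log units; within the scatter). Compound 3 is estimated at 500 nM in this assay, with a range from 150 nM to 2000 nM.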

Compound 3, half-maximal inhibitory concentration: 30 nM
For compound 3 the middle estimate is 17-fold (1.22 log units) above the measured one, outside the stated range (below it).
By their numbers in this assay, from the lowest: compound 3; then compound 2; then compound 1.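

In this assay, the aromatic carbon meta to two methoxy groups and para to a large group proves highly responsive: methoxy in place of hydrogen there gives a 23-fold lower number from compound 2 to compound 3 (1.37 log units; beyond the scatter), so this position is not the near-silent site that compound 2 alone might have suggested. With that three-methoxy ring held constant, the group on the other aromatic ring also carries a large effect, since methoxy in place of chloro gives a 500-fold lower number from compound 1 to compound 3 (2.70 log units; beyond the scatter), and compound 3 now has the lowest number of the series by steps beyond the scatter to both other compounds. Nothing measured alongside these antiproliferative numbers accounts for the size of either step.

The compounds shown leave open whether the step from hydrogen at this position is particular to methoxy or would also appear with a hydroxyl, a fluorine, an amine or a longer chain such as ethoxy. They also leave open how far the two changes act independently, as a single compound pairing chloro on the other ring with hydrogen at this position would be needed to read that directly.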